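A few compounds are considered here, and "the series" means these few. Any claim that something is new, unique, unknown or untested is made for them only; others in the source may bear on it.

Compound 1 `Cc1cccc(Cn2c(CN3CCN(C(=O)c4cccnc4)CC3)nc3ccccc32)c1` gives 24.5% in an assay on isolated protein for inhibition of aldehyde dehydrogenase 1A1 (Homo sapiens), read by spectrophotometry, tested at 10 uM; on this read-out lower numbers stand for less inhibition and higher numbers for more inhibition at the one concentration tested (going by the name of the read-out). Compound 2 `CCC(=O)N1CCN(Cc2nc3ccccc3n2Cc2cccc(C)c2)CC1` gives 85.1% in this assay, a rise of a number 60.6 percentage points higher from compound 1 to compound 2 (beyond the scatter), and so stands highest of the two compounds measured. Compound 3 `Cc1ccc(C(=O)N2CCN(Cc3nc4ccccc4n3Cc3cccc(C)c3)CC2)cc1` differs from compound 2 by 4-methylphenyl in place of ethyl on a carbonyl carbon. Among the measured compounds shown here, the one step that bears on this sits at the same carbonyl carbon: replacing pyridin-3-yl with ethyl gave a number 60.6 percentage points higher from compound 1 to compound 2 (beyond the scatter), so putting an aromatic ring back in place of ethyl is expected to lower the read-out markedly, by about a number 40.1 percentage points lower from compound 2 to compound 3 (beyond the scatter). Compound 3 is therefore estimated at 45%, with a range from 15% to 75%.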

Compound 3, a percentage reported as inhibition, at one concentration (the size of the read-out at that concentration, not a potency): 64.9%
Compound 3: the middle estimate sits 19.9 percentage points below what was measured; the measured number falls inside the stated range.
By their numbers in this assay, from the lowest: compound 1; then compound 3; then compound 2.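

At the carbonyl carbon, an aromatic ring alone does not bring the read-out down to the level of compound 1: in this assay, 4-methylphenyl in place of ethyl gives a number 20.2 percentage points lower from compound 2 to compound 3 (beyond the scatter), while 4-methylphenyl in place of pyridin-3-yl gives a number 40.4 percentage points higher from compound 1 to compound 3 (beyond the scatter). The two aromatic groups thus differ widely at this place, though ethyl in compound 2 remains the highest of the three. Nothing measured here accounts for these differences. The compounds shown leave open how a longer chain than ethyl would read on this carbonyl carbon. They also leave open how an amine or a carboxylic acid carried on the phenyl ring would read there.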